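Swapping a Hydroxyphenyl for a Nitrophenyl in Two Cores

The source may hold more compounds than are shown below. What is called first, only, known or untested is meant among the compounds shown, and "the series" means these compounds.

Compound 2 `CC1=C(C(=O)Nc2ccc(Cl)cc2)C(c2ccccc2O)C(C(=O)Nc2ccc(Cl)cc2)=C(C)N1` and compound 1 `CC1=C(C(=O)Nc2ccc(Cl)cc2)C(c2cccc([N+](=O)[O-])c2)C(C(=O)Nc2ccc(Cl)cc2)=C(C)N1` share one core and differ in a single group: 3-nitrophenyl in place of 2-hydroxyphenyl on a saturated ring carbon. In an ADME assay on Vero cells (Chlorocebus sabaeus) for cytotoxicity, read by sulforhodamine B assay, with a stated time of 3 days (on this read-out lower numbers stand for higher toxicity in this test and higher numbers for lower toxicity in this test), compound 2 gives 62 ug/mL, and compound 1 gives 26 ug/mL, so the swap made a 2.4-fold lower number from compound 2 to compound 1 (0.38 log units; beyond the scatter). Compound 3 `COc1ccc(NC(=O)C2=C(C)NC(=S)NC2c2ccccc2O)cc1` is built on a different core; the difference between the two cores is not broken down here. In this assay compound 3 gives 246 ug/mL, the highest of the three numbers. Compound 4 `COc1ccc(NC(=O)C2=C(C)NC(=S)NC2c2cccc([N+](=O)[O-])c2)cc1` has not yet been measured and differs from compound 3 by 3-nitrophenyl in place of 2-hydroxyphenyl on a saturated ring carbon. The surroundings are not identical: in compound 2 the carbon sits in a ring with 1 nitrogen, next to two ring atoms that each bear a (4-chlorophenyl)carbamoyl group, whereas in compound 3 it sits in a ring with 2 nitrogen, next to the ring nitrogen and next to the ring atom that bears a large group. This is the same kind of change, not the same change. For compound 4 a step of similar size toward a lower number is expected, a 2.2-fold lower number from compound 3 to compound 4 (0.35 log units; beyond the scatter), because the same kind of swap gave a 2.4-fold lower number from compound 2 to compound 1 (0.38 log units; beyond the scatter). Compound 4 is estimated at 110 ug/mL in this assay, with a likely range from 50 ug/mL to 250 ug/mL.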

Compound 4, half-maximal cytotoxic concentration: 80 ug/mL
Beside the measured number, compound 4's estimate is 1.4-fold (0.14 log units) above it, within the range that was stated.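

On the second core the swap acts as it did on the first: in this assay, putting 3-nitrophenyl in place of 2-hydroxyphenyl gives a 3.1-fold lower number from compound 3 to compound 4 (0.49 log units; beyond the scatter), and a lower number here stands for higher toxicity in this test. Set side by side, the two results agree in direction and in size, which suggests the change carries over between these cores: the same change on two cores in this assay, a 2.4-fold lower number (0.38 log units; beyond the scatter) from compound 2 to compound 1 and a 3.1-fold lower number (0.49 log units; beyond the scatter) from compound 3 to compound 4, 1.3-fold (0.11 log units) apart, within the scatter of two such steps Still, two cores are a small sample, so this does not show that the step would hold on a third core, and the numbers alone do not say why the swap lowers the value.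

The compounds shown carry only 2-hydroxyphenyl or 3-nitrophenyl on the saturated ring carbon, so it stays open how a phenyl ring bearing an amine or a carboxylic acid would behave in this assay. Also open is which of the parts that differ between the two cores accounts for any difference in their numbers.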